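This account rests on a few compounds, and the source may have more. Where it says the series, first, only, none or still open, it means among the compounds named here.

Of the compounds shown here, three of this study have so far been measured in a functional assay on K562 cells (Homo sapiens), read by MTT assay, with a stated time of 72 h; on this read-out higher numbers stand for weaker inhibition and lower numbers for stronger inhibition. Compound 1 `O=c1[nH]cnc2c1c(-c1ccsc1)cn2[C@@H]1O[C@H](CO)[C@@H](O)[C@H]1O` carries a thiophen-3-yl group on its core. In this assay compound 1 gives > 20000 nM, which is a limit of the assay and not a number. Compound 1 therefore stands at the limit of > 20000 nM in this assay, at which 1 of the 3 values shown sits, and nothing more precise is known of it. Compound 2 `COc1ncnc2c1c(-c1cccs1)cn2[C@@H]1O[C@H](CO)[C@@H](O)[C@H]1O` gives 70 nM in this assay. Compound 3 `Cc1nc(N)c2c(-c3cc4ccccc4o3)cn([C@@H]3O[C@H](CO)[C@@H](O)[C@H]3O)c2n1` gives 15700 nM in this assay. Within the data shown here, no two of these three differ in a single place, so no measured step connects them.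

Compound 4 `O=c1[nH]cnc2c1c(-c1ccccc1)cn2[C@@H]1O[C@H](CO)[C@@H](O)[C@H]1O` is not yet measured. It differs from compound 1 in one place: phenyl in place of thiophen-3-yl on an aromatic carbon. Among the measured compounds shown here, because compound 1 sits at the limit of > 20000 nM in this assay, at which 1 of the 3 values shown sits, there is no number from which the effect of this change could be counted, and none of the measured compounds shows what a phenyl does here. The expectation is that the step from compound 1 to compound 4 remains small, a number no higher from compound 1 to compound 4 (the limit leaves the size open), no larger than the scatter of repeated measurements. Compound 4 is thus expected to give about 20000 nM in this assay, somewhere between 5000 nM and 60000 nM, with a real chance that only a limit is reported again.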

Compound 4, half-maximal inhibitory concentration: > 20000 nM
Compound 4: no number, only a limit; the forecaster's own chance of this, stated with the estimate: 65%; the middle value sits exactly at the limit.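

Compound 1 and compound 4 both give only a limit of the assay and not a number, so no step between them can be read in this assay: the limit of > 20000 nM in this assay, at which 2 of the 4 values shown sit.

The compounds shown leave open whether phenyl and thiophen-3-yl on the shared core differ at all in this read-out.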